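The source may hold more compounds than are shown below. What is called first, only, known or untested is meant among the compounds shown, and "the series" means these compounds.

Measured compounds:

compound 1, `CCC(c1ccccc1)c1nc(-c2ccc(Cl)cc2)c(CC(=O)O)s1`: in an in vitro assay on HEK385-7 cells for displacement of a labelled ligand from prostaglandin D2 receptor 2 (Homo sapiens) (on this read-out higher numbers stand for weaker inhibition and lower numbers for stronger inhibition), compound 1 gives 190 nM
compound 2, `O=C(O)Cc1sc(C(c2ccc(F)cc2)c2ccc(F)cc2)nc1-c1cc(F)cc(F)c1`: compound 2 gives 35 nM
compound 3, `O=C(O)Cc1sc(C(c2ccc(F)cc2)c2ccc(F)cc2)nc1-c1ccoc1`: compound 3 gives 14 nM

Compound 3 has the lowest number of the three, which on this read-out means the strongest inhibition. For the measured compounds named here, its nearest neighbour is compound 2, and the only single-point step in the set runs between them: a 2.5-fold lower number from compound 2 to compound 3 (0.40 log units; beyond the scatter). Going by the values given here, compound 1, which differs from the others in more than one place, shows a clearly higher number than compound 3, but no single step links the two.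

Compound 4, `O=C(O)Cc1sc(C(c2ccc(F)cc2)c2ccc(F)cc2)nc1-c1ccnc(Cl)c1`, is the next compound to be measured in this assay. It differs from compound 3 in one place: 2-chloropyridin-4-yl in place of furan-3-yl on an aromatic carbon. Among the compounds with values here, the step that bears on this change is the one from compound 2 to compound 3, where a six-membered aromatic ring on that aromatic carbon was replaced by the five-membered furan-3-yl and the number fell modestly. Compound 4 returns a six-membered aromatic ring to the same aromatic carbon, so a modest step upward, roughly undoing that gain, is expected, though a chloropyridine ring has not been measured here and the outcome could also stay within the scatter. For compound 4 the expected step is a 2.0-fold higher number from compound 3 to compound 4 (0.30 log units; within the scatter), giving an estimate of 28 nM, with a range from 10 nM to 90 nM.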

Compound 4, half-maximal inhibitory concentration: 3.1 nM
Beside the measured number, compound 4's estimate is 9.0-fold (0.96 log units) above it; measured number below the stated range.
By their numbers in this assay, from the lowest: compound 4; then compound 3; then compound 2; then compound 1.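

In this assay, putting 2-chloropyridin-4-yl in place of furan-3-yl on this aromatic carbon, next to the ring nitrogen, gives a 4.5-fold lower number from compound 3 to compound 4 (0.65 log units; beyond the scatter) and so the number falls further instead of rising, which shows that a six-membered aromatic ring here need not give up the level reached with the five-membered furan-3-yl. Against the 3,5-difluorophenyl ring, the same group gives an 11-fold lower number from compound 2 to compound 4 (1.05 log units; beyond the scatter) and that step is larger than a 2.5-fold lower number from compound 2 to compound 3 (0.40 log units; beyond the scatter) on the same carbon, so ring size alone does not order these groups: the six-membered rings of compound 2 and compound 4 stand at the two ends of this series of three. The change from compound 3 to compound 4 also adds heavy atoms, and at this position that addition came with a lower number, not a higher one.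

Going by these compounds, how a plain pyridin-4-yl, or a 2-methoxypyridin-4-yl or 2-aminopyridin-4-yl with another group in the place of the chlorine, would read stays open, so the shares of the chlorine and the ring nitrogen in this change cannot be separated. Nothing shown here gives a measured reason for the fall in the number.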